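The source may report more compounds than this note shows. Statements on the series, on what has been measured and on what is new or still open speak of the compounds shown alone.

Measured in a functional assay on MCF7 cells (Homo sapiens) for antiproliferative activity, read by MTT assay, with a stated time of 72 h; on this read-out higher numbers stand for weaker inhibition and lower numbers for stronger inhibition:
- Compound 1 `Cc1ccc(N(C)S(=O)(=O)C2CC3OC2C(c2ccc(NC(=O)CCCCCCC(=O)O)cc2)=C3c2ccc(O)cc2)cc1` gives 23200 nM
- Compound 2 `Cc1cccc(N(C)S(=O)(=O)C2CC3OC2C(c2ccc(NC(=O)CCCCCCC(=O)O)cc2)=C3c2ccc(O)cc2)c1` gives 30200 nM
- Compound 3 `CN(c1ccccc1Cl)S(=O)(=O)C1CC2OC1C(c1ccc(NC(=O)CCCCCCC(=O)O)cc1)=C2c1ccc(O)cc1` gives 12800 nM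

Compound 3 sits at the low end of these numbers, but only part of that position is clear. The change in the aryl group on the sulfonamide nitrogen gives a 2.4-fold lower number from compound 2 to compound 3 (0.37 log units; beyond the scatter), a modest step, whereas it gives a 1.8-fold lower number from compound 1 to compound 3 (0.26 log units; within the scatter). The remaining swap gives a 1.3-fold higher number from compound 1 to compound 2 (0.11 log units; within the scatter).

The next compound is compound 4 `CN(c1cccc2ccccc12)S(=O)(=O)C1CC2OC1C(c1ccc(NC(=O)CCCCCCC(=O)O)cc1)=C2c1ccc(O)cc1`, with naphthalen-1-yl in place of 2-chlorophenyl on a sulfonamide nitrogen. Among the measured compounds shown here, all three measured steps bear on this change, since each swaps only this aryl group, yet none of them involves a naphthalen-1-yl group. They are small, so no step beyond the scatter is expected in this assay, and no direction is favoured with any confidence.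

The estimated step is a 1.2-fold higher number from compound 3 to compound 4 (0.07 log units; within the scatter).

Compound 4 is expected at 15000 nM, within an estimated range from 6500 nM to 32000 nM.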

Compound 4, half-maximal inhibitory concentration: 14000 nM
Compound 4: the middle estimate sits 1.1-fold (0.03 log units) above what was measured, within the range that was stated.
By their numbers in this assay, from the lowest: compounds 3, 4, 1 and 2 (each within the scatter of the next, the first and the last beyond it).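

In this assay, a second aromatic ring can stand on the sulfonamide nitrogen, with naphthalen-1-yl (10 heavy atoms, no chlorine) replacing 2-chlorophenyl (7 heavy atoms, one chlorine) for a 1.1-fold higher number from compound 3 to compound 4 (0.04 log units; within the scatter). Against the two methylphenyl compounds, the naphthalen-1-yl group gives a 2.2-fold lower number from compound 2 to compound 4 (0.33 log units; beyond the scatter) and a 1.7-fold lower number from compound 1 to compound 4 (0.22 log units; within the scatter), so only the comparison with 3-methylphenyl goes beyond the scatter, as it did for 2-chlorophenyl. Nothing measured here accounts for these steps.

The compounds shown leave open what an aryl group bearing an amine or a hydroxyl, or a plain alkyl group, would give at this nitrogen. On these data alone, all four compounds also keep the same chain ending in a carboxylic acid, so the effect of a hydroxamic acid or a shorter chain there remains unknown.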